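This account rests on a few compounds, and the source may have more. Where it says the series, first, only, none or still open, it means among the compounds named here.

Measured so far:
compound 1, `NS(=O)(=O)c1ccc(-c2nc(SCCOC(=O)/C=C/c3ccc(O)c(O)c3)nn2-c2ccccc2)cc1`, 800 nM
compound 2, `NS(=O)(=O)c1ccc(-c2nc(SCCCOC(=O)/C=C/c3ccc(O)c(O)c3)nn2-c2ccccc2)cc1`, 770 nM
compound 3, `COc1cc(/C=C/C(=O)OCCSc2nc(-c3ccc(S(C)(=O)=O)cc3)n(-c3ccc(Br)cc3)n2)ccc1OC(C)=O`, 940 nM

All three were run in an assay on cells (strain Sprague-Dawley) for inhibition of Polyunsaturated fatty acid 5-lipoxygenase (Rattus norvegicus), with a stated time of 30 min; a lower number here means a stronger inhibitor, a higher number a weaker inhibitor. Compound 3 sits together with the other two: its number and that of compound 1 differ by a gap within the scatter, and the gap from compound 3 to compound 2 is also within the scatter, so no order among the three can be read from these numbers.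

The next member, compound 4, `COc1cc(/C=C/C(=O)OCCSc2nc(-c3ccc(S(C)(=O)=O)cc3)n(-c3ccc(C(F)(F)F)cc3)n2)ccc1OC(C)=O`, differs from compound 3 in one place: trifluoromethyl in place of bromo on an aromatic carbon. Going by the values given here, no measured pair shows this change, so there is no step to lean on. The expectation is a step of a 1.0-fold lower number from compound 3 to compound 4 (0.02 log units; within the scatter), not beyond the scatter in either direction. Compound 4 is estimated at 900 nM, within a range from 400 nM to 2000 nM.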

Compound 4, half-maximal inhibitory concentration: 920 nM
Beside the measured number, compound 4's estimate is 1.0-fold (0.01 log units) below it; measured number inside the range.
By their numbers in this assay, from the lowest: compounds 2, 1, 4 and 3 (each within the scatter of the next).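

Trifluoromethyl in place of bromo, on an aromatic carbon para to a large group, gives a 1.0-fold lower number from compound 3 to compound 4 (0.01 log units; within the scatter) in this assay and is the only one-place comparison shown. At this position, going from 1 heavy atom to 4 separates the two compounds by no more than the scatter. No supporting measurement bears on this result.

On these data alone, whether an amine or a carboxylic acid on this carbon would stay in the same range remains open. So does whether the same exchange would give a similar step on the core of compound 1.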